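From compound 3 to compound 4: a measurable value expected

The compounds below may be only part of what the source reports. "The series", "measured", "known", "first", "only" and "open" are said of these compounds alone.

compound 1 `COc1cc(NC(C)CCCNC(=O)Nc2ccc(Br)cc2)c2ncccc2c1`: 23000 nM
compound 2 `COc1cc(NC(C)CCCNC(=O)NNC(=O)Nc2ccc(F)cc2)c2ncccc2c1`: >= 250000 nM (a limit)
compound 3 `COc1cc(NC(C)CCCNC(=O)NNC(=O)Nc2ccc(Cl)cc2)c2ncccc2c1`: >= 250000 nM (a limit)

All three values come from a functional assay on MIA PaCa-2 cells (Homo sapiens) for inhibition, read by MTT assay, with a stated time of 72 h; on this read-out lower numbers stand for stronger inhibition and higher numbers for weaker inhibition. Compound 3 has no number, only the limit >= 250000 nM. Compound 2 and compound 3 both rest on (the limit of >= 250000 nM in this assay, at which 2 of the 3 values shown sit), which leaves a step that the two limits leave unreadable from compound 2 to compound 3.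

Compound 4 `COc1cc(NC(C)CCCNC(=O)Nc2ccc(C(F)(F)F)cc2)c2ncccc2c1` differs from compound 3 as follows: 4-(trifluoromethyl)phenyl in place of ((4-chlorophenyl)carbamoyl)amino on an amide-type nitrogen. In words, 4-(trifluoromethyl)phenyl stands in place of ((4-chlorophenyl)carbamoyl)amino on an amide-type nitrogen, which matches compound 1, where 4-bromophenyl sits on that nitrogen.

The closest evidence runs the opposite way: an at least 10-fold higher number from compound 1 to compound 3 (1.03 log units; beyond the scatter), and likewise an at least 10-fold higher number from compound 1 to compound 2 (1.03 log units; beyond the scatter). Both are large and both end at a limit. Reversing that change, a large move to lower numbers is expected in this assay, bringing the result near compound 1 at 23000 nM. The expected step is an at least 12-fold lower number from compound 3 to compound 4 (1.09 log units; beyond the scatter). For compound 4 the estimate is 20000 nM, with an expected range of 7000 nM to 60000 nM.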

Compound 4, half-maximal inhibitory concentration: 8400 nM
For compound 4 the middle estimate is 2.4-fold (0.38 log units) above the measured one; the measured number falls inside the stated range.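

On the amide-type nitrogen, a directly attached 4-(trifluoromethyl)phenyl restores a readable value in this assay, with an at least 29-fold lower number from compound 3 to compound 4 (1.47 log units; beyond the scatter) and an at least 29-fold lower number from compound 2 to compound 4 (1.47 log units; beyond the scatter). Both steps start from a limit, not a number: the limit of >= 250000 nM in this assay, at which 2 of the 4 values shown sit.
Among the compounds shown here, with trifluoromethyl in place of bromo on an aromatic carbon, a 2.7-fold lower number from compound 1 to compound 4 (0.44 log units; beyond the scatter) is the first readable step for a change on that aromatic carbon, and it lies beyond the scatter.

On these data alone, only bromo and trifluoromethyl are readable there, so how an amine or a carboxylic acid on that carbon would read stays open. Also open, as far as these compounds go, is whether a longer chain on the shared core would keep the activity of compound 4.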